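The source may hold more compounds than are shown below. What is called first, only, known or untested is meant among the compounds shown, and "the series" means these compounds.

Values measured in a functional assay on blood (Homo sapiens), with a stated time of 60 min, in the presence of a further agent that is not named here (a higher number here means that more compound is needed for the effect, a lower number that less compound is needed), each of them a limit of the assay and not a number:

Compound 1 `O=S(=O)(c1ccc(Oc2ccc(OC(F)(F)F)cc2)cc1)C1CCC2(CCNCC2)C1`: > 15000 nM
Compound 2 `O=C(OCc1ccccc1)C1(S(=O)(=O)c2ccc(Oc3ccc(OC(F)(F)F)cc3)cc2)CCC2(CCNCC2)C1`: > 15000 nM
Compound 3 `O=C(Nc1nccs1)C1(S(=O)(=O)c2ccc(Oc3ccc(OC(F)(F)F)cc3)cc2)CCC2(CCNCC2)C1`: > 15000 nM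

In this assay compound 3 stands at > 15000 nM, which is a limit. It shares this position with the other two compounds, as the whole set sits at the limit of > 15000 nM in this assay, at which 3 of the 3 values shown sit. Compound 3 therefore cannot be ranked against either of them.

Compound 4 `O=C(Nc1ccccn1)C1(S(=O)(=O)c2ccc(Oc3ccc(OC(F)(F)F)cc3)cc2)CCC2(CCNCC2)C1` keeps the shared core and the carbamoyl link of compound 3. It has pyridin-2-yl in place of 1,3-thiazol-2-yl on an amide-type nitrogen.

The nearest measured change is a step that the two limits leave unreadable from compound 2 to compound 3, which altered the group on the same carbonyl carbon. Also relevant are a step that the two limits leave unreadable from compound 1 to compound 3 and a step that the two limits leave unreadable from compound 1 to compound 2. None of these has a readable size or direction, so none shows that this part of the structure moves the value in this assay.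

No step beyond the usual scatter is therefore expected, and the expected change is a number no higher from compound 3 to compound 4 (the limit leaves the size open). A further limit is the most likely report. For compound 4 the estimated value is 15000 nM, with an expected range from 5000 nM to 30000 nM.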

Compound 4, half-maximal effective concentration: > 15000 nM
Compound 4: only a limit was reported; the forecaster's own chance of this, stated with the estimate: 80%; the middle value sits exactly at the limit.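

In this assay compound 4 gives > 15000 nM, which is a limit and not a number. No step among compound 1, compound 2, compound 3 and compound 4 can be read, as all of them sit at the same limit: the limit of > 15000 nM in this assay, at which 4 of the 4 values shown sit.

The compounds shown leave open whether any of these groups on the shared core moves the value in this assay at all, and in which direction.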